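Swapping 2-methoxyphenyl for pyridin-3-yl in a small series

A few compounds are considered here, and "the series" means these few. Any claim that something is new, unique, unknown or untested is made for them only; others in the source may bear on it.

In a functional assay on cells (Platelet, Homo sapiens) for inhibition (on this read-out higher numbers stand for weaker inhibition and lower numbers for stronger inhibition), compound 1 `CCOC(=O)c1ccc(-c2nn(Cc3cccc(Cl)c3)c3ccccc23)cc1` gives 80 nM and compound 2 `CCOC(=O)c1ccc(-c2nn(Cc3ccc(Cl)cc3)c3ccccc23)cc1` gives 120 nM, a pair separated only by a 1.5-fold higher number from compound 1 to compound 2 (0.18 log units; within the scatter). Compound 3 `CCOC(=O)c1ccc(-c2nn(Cc3ccccc3OC)c3ccccc23)cc1` gives 470 nM, the highest number of the three and so the weakest inhibition among them. The next structure, compound 4 `CCOC(=O)c1ccc(-c2nn(Cc3cccnc3)c3ccccc23)cc1`, keeps the shared core and has pyridin-3-yl in place of 2-methoxyphenyl on a saturated chain carbon bound to an aromatic nitrogen, (pyridin-3-yl in place of 2-methoxyphenyl on a saturated chain carbon bound to an aromatic nitrogen).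

Two measured steps change the group at this same place: a 5.9-fold higher number from compound 1 to compound 3 (0.77 log units; beyond the scatter) and a 3.9-fold higher number from compound 2 to compound 3 (0.59 log units; beyond the scatter). Both show that a change there can move the number modestly beyond the scatter. For the measured compounds named here, neither gives a direct reading of the new group, however, since no measured compound carries a ring with a hetero atom at this place. Compound 4 also has no chlorophenyl group, and nothing in the data suggests that it will reach the numbers of the two chlorinated compounds. The expected change is a 1.3-fold higher number from compound 3 to compound 4 (0.11 log units; within the scatter), a small rise that is not expected to leave the scatter. For compound 4 the estimated value is 600 nM, with an expected range from 180 nM to 2000 nM.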

Compound 4, half-maximal inhibitory concentration: 5550 nM
Compound 4: the middle estimate sits 9.3-fold (0.97 log units) below what was measured, and the stated range ends below it.
By their numbers in this assay, from the lowest: compounds 1 and 2 (each within the scatter of the next); then compound 3; then compound 4.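

For the compounds shown here, compound 4 shows that, in this assay, the place on a saturated chain carbon bound to an aromatic nitrogen can move the number much further than the earlier compounds revealed: the change from 2-methoxyphenyl to pyridin-3-yl gives a 12-fold higher number from compound 3 to compound 4 (1.07 log units; beyond the scatter) and is rated large, whereas the steps among the three earlier compounds were at most modest. Going by these compounds alone, measured against the chlorinated compounds the change is larger still, with a 46-fold higher number from compound 2 to compound 4 (1.67 log units; beyond the scatter) and a 69-fold higher number from compound 1 to compound 4 (1.84 log units; beyond the scatter) in the same assay, leaving compound 4 as the weakest inhibitor of the four and the first compound with a hetero atom in the ring at this place. No supporting data are available to account for this change in the number.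

The compounds shown do not separate the effect of the ring nitrogen from the loss of the chlorine or methoxy substituent, since compound 4 differs from the others in both respects. A plain phenyl, a chloro-substituted pyridin-3-yl or a pyridin-4-yl at this place would help to tell these apart.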